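This account rests on a few compounds, and the source may have more. Where it says the series, first, only, none or still open, it means among the compounds named here.

Working notes on the series

The series shares one core carrying a benzamide-type hydrazide on the ring nitrogen and a para-halophenyl on the fused pyrazole; three members have been measured so far, and a fourth awaits measurement. Compound 1 `COc1cccc(-c2nc3c(-c4ccc(Cl)cc4)n[nH]c3c(=O)n2NC(=O)c2ccncc2)c1` in a functional assay on HT-29 cells (Homo sapiens) for cytotoxicity, read by sulforhodamine B assay, with a stated time of 2 days, tested at 100 uM (on this read-out lower numbers stand for less inhibition and higher numbers for more inhibition at the one concentration tested (going by the name of the read-out)), gives 46%. Compound 2 `O=C(Nn1c(-c2cccc([N+](=O)[O-])c2)nc2c(-c3ccc(F)cc3)n[nH]c2c1=O)c1ccccc1` in this assay gives 92%. Compound 3 `O=C(Nn1c(CCc2ccccc2)nc2c(-c3ccc(Cl)cc3)n[nH]c2c1=O)c1ccccc1` in this assay gives 86.5%, which places it second of the three numbers, within the scatter of compound 2 and well beyond the scatter above compound 1.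

Compound 4 `O=C(Nn1c(CCC2CCCC2)nc2c(-c3ccc(Cl)cc3)n[nH]c2c1=O)c1ccccc1` differs from compound 3 in one place only: cyclopentyl in place of phenyl on a saturated chain carbon, two bonds along the chain from an aromatic carbon. The phenethyl chain of compound 3 thus becomes a 2-cyclopentylethyl chain, with the rest of the molecule unchanged. Within the data shown here, no measured pair in the set isolates this kind of change, so the expected step rests on compound 3 alone and on the spread of the three measured values.

The change from compound 3 to compound 4 is expected to give a modest downward step, likely within or only just beyond the scatter, as a number 8.5 percentage points lower from compound 3 to compound 4 (within the scatter). Compound 4 is therefore estimated at 78% in this assay, with a range from 55% to 95%.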

Compound 4, a percentage reported as inhibition, at one concentration (the size of the read-out at that concentration, not a potency): 87.3%
For compound 4 the middle estimate is 9.3 percentage points below the measured one; the measured number falls inside the stated range.
By their numbers in this assay, from the lowest: compound 1; then compounds 3, 4 and 2 (each within the scatter of the next).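

In this assay, exchanging phenyl for cyclopentyl on a saturated chain carbon, two bonds along the chain from an aromatic carbon, gives a number 0.8 percentage points higher from compound 3 to compound 4 (within the scatter) and so leaves the read-out unchanged within the scatter. For this pair, an aromatic ring at the end of the chain is therefore not needed to keep the inhibition seen at the one concentration tested, and a five-membered non-aromatic ring of carbon only takes the place of the six-membered aromatic one with one heavy atom fewer. Among these compounds, this is the first pair that differs in one place, and the data hold nothing that explains why the two rings read alike.

On these data alone, both rings are carbon only and carry no hydrogen-bond donors or acceptors, so it remains open whether the chain end would accept a basic amine such as piperidine, a carboxylic acid, or a longer chain between the core and the ring. A percentage at a single concentration also leaves open whether compound 3 and compound 4 would still read alike in a full concentration series.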